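Diethylamino in place of dimethylamino on the benzylic chain

A few compounds are considered here, and "the series" means these few. Any claim that something is new, unique, unknown or untested is made for them only; others in the source may bear on it.

Compound 1 `COc1ccccc1-c1cc(C2CCNC2)ccc1Cl`: 590 nM in an assay on isolated protein for binding affinity to 5-hydroxytryptamine receptor 3A (Homo sapiens); on this read-out lower numbers stand for stronger inhibition and higher numbers for weaker inhibition
Compound 2 `COc1ccccc1-c1cc(C2CCN(C)C2)ccc1Cl`: 420 nM in this assay
Compound 3 `COc1ccccc1-c1cc(CN(C)C)ccc1Cl`: 1000 nM in this assay

Compound 3 carries the highest of the three numbers; the gap to its nearest neighbour is a 1.7-fold higher number from compound 1 to compound 3 (0.23 log units; within the scatter), and the gap to its furthest is a 2.4-fold higher number from compound 2 to compound 3 (0.38 log units; beyond the scatter). Compound 4 `CCN(CC)Cc1ccc(Cl)c(-c2ccccc2OC)c1` has not yet been measured. It differs from compound 3 in one place: diethylamino in place of dimethylamino on a saturated chain carbon bound to an aromatic carbon.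

Among the compounds with values here, no measured step touches the substituents on this chain nitrogen. The closest parallel is the addition of a methyl to the ring amine nitrogen, a 1.4-fold lower number from compound 1 to compound 2 (0.15 log units; within the scatter), which stayed within the scatter. The two other steps, a 1.7-fold higher number from compound 1 to compound 3 (0.23 log units; within the scatter) and a 2.4-fold higher number from compound 2 to compound 3 (0.38 log units; beyond the scatter), exchange the whole group rather than the alkyls on the nitrogen, so they say little about a move from dimethyl to diethyl. On this basis compound 4 is expected to sit close to compound 3, with no step beyond the scatter in this assay, and the estimated step is a 1.2-fold higher number from compound 3 to compound 4 (0.08 log units; within the scatter). The estimate for compound 4 is 1200 nM, with a range from 500 nM to 3000 nM.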

Compound 4, inhibition constant: > 10000 nM
Compound 4: a limit, no number; the forecaster's own chance of this, stated with the estimate: 5%; middle value at least 8.3-fold (0.92 log units) away from the limit.
By their numbers in this assay, from the lowest: compounds 2, 1 and 3 (each within the scatter of the next, the first and the last beyond it). At a limit, above all of these: compound 4.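

Compound 4 gives a limit and not a number in this assay: the limit of > 10000 nM in this assay, at which 1 of the 4 values shown sits. Within the data shown here, the earlier compounds held no change on the chain nitrogen, and this one shows that the alkyl groups there are not a free choice: diethylamino in place of dimethylamino on a saturated chain carbon bound to an aromatic carbon brings an at least 10-fold higher number from compound 3 to compound 4 (1.00 log units; beyond the scatter), whereas the one change on an amine nitrogen seen before, the methyl on the ring nitrogen, stayed within the scatter. Set against the ring-bearing compounds, (diethylamino)methyl also falls well short, with an at least 23-fold higher number from compound 2 to compound 4 (1.37 log units; beyond the scatter) and an at least 16-fold higher number from compound 1 to compound 4 (1.22 log units; beyond the scatter), so compound 4 is the only compound of the series with a large step from the others.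

As far as these compounds go, since compound 4 stands at a limit, the true size of these steps remains open, as does the question of whether a single ethyl, as in ethyl(methyl)amino, already has the same effect as diethylamino. The compounds shown also leave open how a pyrrolidin-1-yl on the same chain carbon would read, and whether a 1-ethylpyrrolidin-3-yl would follow the open-chain diethylamino or stay with the ring compounds.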